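Oxadiazole ketone series: ring attachment swap at the carbonyl

The source may hold more compounds than are shown below. What is called first, only, known or untested is meant among the compounds shown, and "the series" means these compounds.

Measured compounds:
compound 1 `O=C(CCCCCCc1ccccc1)c1ncno1` 1 nM
compound 2 `O=C(CCCCCCc1ccccc1)c1nc(-c2ccccn2)no1` 0.34 nM
compound 3 `O=C(CCCCCCc1ccccc1)c1nc(-c2ccco2)no1` 1 nM

Going by the values given here, in an assay for inhibition of Fatty-acid amide hydrolase 1 (Rattus norvegicus), at pH 9.0 (on this read-out lower numbers stand for stronger inhibition and higher numbers for weaker inhibition), compound 1 is level with compound 3, and the two together give the highest numbers of the three; the only step beyond the scatter is a 2.9-fold lower number from compound 1 to compound 2 (0.47 log units; beyond the scatter). Compound 4 `O=C(CCCCCCc1ccccc1)c1ncon1` differs from compound 1 by 1,2,4-oxadiazol-3-yl in place of 1,2,4-oxadiazol-5-yl on a carbonyl carbon. The measured steps, no change at the digits printed from compound 1 to compound 3 (within the scatter) and a 2.9-fold higher number from compound 2 to compound 3 (0.47 log units; beyond the scatter), concern substituents on the ring, not its point of attachment, so none of them bears on this change. A step is expected in this assay, its direction uncertain, and the estimate for compound 4 is therefore given a wide range: 10 nM with 1 nM to 100 nM, which would mean a 10-fold higher number from compound 1 to compound 4 (1.00 log units; beyond the scatter).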

Compound 4, inhibition constant: 7 nM
The estimate for compound 4 lay 1.4-fold (0.15 log units) above the measured number; measured number inside the range.
By their numbers in this assay, from the lowest: compound 2; then compounds 1 and 3 (each within the scatter of the next); then compound 4.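

Attachment to the carbonyl carbon matters in this assay: with the same atoms joined differently, 1,2,4-oxadiazol-3-yl in place of 1,2,4-oxadiazol-5-yl gives a 7.0-fold higher number from compound 1 to compound 4 (0.85 log units; beyond the scatter). Going by these compounds alone, the earlier steps changed only ring substituents, so this is the first evidence that the point of attachment itself counts. No evidence at hand accounts for this step.

Open, as far as these compounds go, is whether pyridin-2-yl or furan-2-yl on the 1,2,4-oxadiazol-3-yl ring would act as on the 1,2,4-oxadiazol-5-yl ring. Also open, from the compounds shown here alone, is the effect of a carboxylic acid on the pyridin-2-yl ring of compound 2.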